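Replacing the Amino Group with Nitro on a Boronate Inhibitor

The source may hold more compounds than are shown below. What is called first, only, known or untested is meant among the compounds shown, and "the series" means these compounds.

Compound 3 `CC1(C)C2CC1[C@]1(C)OB([C@H](CCCN=C(N)N)NC(=O)c3ccc(-c4ccccc4)c(N)c3)O[C@@H]1C2` gives 4.7 nM in an assay on isolated protein for inhibition of serine protease 1 (Homo sapiens) (on this read-out higher numbers stand for weaker inhibition and lower numbers for stronger inhibition), the lowest of the three numbers recorded. Compound 2 `CC(C)(C)OC(=O)Nc1cccc(-c2ccc(C(=O)N[C@@H](CCCN=C(N)N)B3O[C@@H]4CC5CC(C5(C)C)[C@]4(C)O3)s2)c1` gives 13 nM in this assay, and compound 1 `CC1(C)C2CC1[C@]1(C)OB([C@H](CCCN=C(N)N)NC(=O)c3ccc(-c4ccccc4)cc3)O[C@@H]1C2` gives 33 nM. Among the measured compounds shown here, the only step between two measured compounds that differ in a single place runs from compound 1 to compound 3: a 7.0-fold lower number from compound 1 to compound 3 (0.85 log units; beyond the scatter).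

Compound 4 `CC1(C)C2CC1[C@]1(C)OB([C@H](CCCN=C(N)N)NC(=O)c3ccc(-c4ccccc4)c([N+](=O)[O-])c3)O[C@@H]1C2` differs from compound 3 in one place: nitro in place of amino on an aromatic carbon. For the measured compounds named here, no measured pair shows this exchange directly. Going by the values given here, the one measured step bears on it only indirectly, because a 7.0-fold lower number from compound 1 to compound 3 (0.85 log units; beyond the scatter) shows that a change at this very carbon moves the number well beyond the scatter, while saying nothing about how nitro compares with amino there. With the amino group gone, compound 4 is expected to give back part of that gain and to sit between the numbers of compound 3 and compound 1, closer to compound 3. For compound 4 the expected step is a 3.2-fold higher number from compound 3 to compound 4 (0.50 log units; beyond the scatter). Compound 4 is therefore estimated at 15 nM in this assay, within a range from 4 nM to 60 nM.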

Compound 4, inhibition constant: 4.8 nM
Compound 4: the middle estimate sits 3.1-fold (0.49 log units) above what was measured, and the stated range covers the measured number.
By their numbers in this assay, from the lowest: compounds 3 and 4 (each within the scatter of the next); then compound 2; then compound 1.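

In this assay, among the compounds shown here, exchanging amino for nitro on this aromatic carbon, ortho to a phenyl group, gives a 1.0-fold higher number from compound 3 to compound 4 (0.01 log units; within the scatter) and so leaves the two groups indistinguishable, a result that the earlier compounds could not show. The hydrogen-to-amino step now has a counterpart in a 6.9-fold lower number from compound 1 to compound 4 (0.84 log units; beyond the scatter) and, like a 7.0-fold lower number from compound 1 to compound 3 (0.85 log units; beyond the scatter) beside it, this lies beyond the scatter, so the lower number relative to compound 1 appears with either group at this carbon. Since nitro has 0 hydrogen-bond donors, a hydrogen-bond donor on this carbon is not needed for that lower number in this pair of compounds, but no measurement offered here accounts for the match between compound 3 and compound 4.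

On these data alone, whether other groups at this carbon, such as a methoxy group, a nitrile or a carboxylic acid, would give numbers like those of compound 3 and compound 4 or like that of compound 1 remains open. The compounds shown also leave open whether a nitro or amino group would have the same effect on the core of compound 2, whose steps to the other compounds cannot be read.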